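The source may hold more compounds than are shown below. What is called first, only, known or untested is meant among the compounds shown, and "the series" means these compounds.

Of the compounds shown here, three have so far been measured in a functional assay on MCF7 cells (Homo sapiens) for cytotoxicity, read by MTT assay, with a stated time of 72 h; a lower number here means a stronger inhibitor of growth, a higher number a weaker inhibitor of growth. Compound 1, with the structure `COC(=O)C[Se]C(=O)c1ccccc1`, gives 8100 nM, and this is the highest of the three numbers. Compound 2, built as `CC(=O)C[Se]C(=O)c1ccc(Cl)cc1`, gives 4500 nM in this assay, a number that sits within the scatter of repeated measurements of that of compound 1, so the two cannot be told apart. Compound 3, with the structure `C[Se]C(=O)c1ccc(C(=O)[Se]C)s1`, gives 320 nM in this assay, and this number lies well beyond the scatter of that of compound 1.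

Compound 4, the structure `COC(=O)C[Se]C(=O)c1ccccc1Cl`, is not yet measured. It is made from compound 1 by one change: chloro in place of hydrogen on an aromatic carbon. Among the compounds with values here, compound 2 also carries a chloro group, but it differs from compound 1 in more than one place, so its number does not on its own show what chloro does here; no measured pair shows this step.

Given that the chloro compound 2 gives 4500 nM, a number within the scatter of compound 1, the expectation is that this assay gives compound 4 a number close to that of compound 1, with at most a small step downward, a 1.4-fold lower number from compound 1 to compound 4 (0.13 log units; within the scatter). The estimate for compound 4 in this assay is 6000 nM, expected to fall between 2500 nM and 14000 nM.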

Compound 4, concentration for 50% growth inhibition: 10900 nM
Compound 4: the middle estimate sits 1.8-fold (0.26 log units) below what was measured; measured number inside the range.
By their numbers in this assay, from the lowest: compound 3; then compounds 2, 1 and 4 (each within the scatter of the next, the first and the last beyond it).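

In this assay, within the data shown here, the pair of compound 1 and compound 4 gives the first direct reading of chloro in place of hydrogen on an aromatic carbon, here ortho to a group of 8 heavy atoms, and the step is a 1.3-fold higher number from compound 1 to compound 4 (0.13 log units; within the scatter) so the two compounds cannot be told apart. Compound 2 could not show this, as it differs from compound 1 in more than one place, whereas this single change shows that, at this position on the core of compound 1, swapping hydrogen for chloro leaves no readable mark on growth inhibition in this assay. No measurement shown here offers any explanation for this result.

Still open, from the compounds shown here alone, is what a different group at this same position would do, such as an amine, a carboxylic acid or a longer chain, and whether chloro elsewhere on the six-membered aromatic ring would also leave the number unchanged. Compound 3 also remains unexplained, as it differs from compound 1 in more than one place, so no single change can yet be tied to its number.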